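Chloro in place of hydrogen on compound 2

The compounds below may be only part of what the source reports. "The series", "measured", "known", "first", "only" and "open" are said of these compounds alone.

Values in a functional assay on MCF7 cells (Homo sapiens) for antiproliferative activity, read by MTT assay, with a stated time of 72 h; on this read-out higher numbers stand for weaker inhibition and lower numbers for stronger inhibition:
- compound 1 `O=C(Nc1ccc(Nc2nccc(NC3CC3)n2)cc1)Nc1ccc(Cl)c(C(F)(F)F)c1`: 38300 nM
- compound 2 `O=C(Nc1ccc(Nc2nccc(Nc3ccccc3)n2)cc1)Nc1ccc(Cl)c(C(F)(F)F)c1`: > 50000 nM, a limit of the assay and not a number

Compound 2 is known only through (the limit of > 50000 nM in this assay, at which 1 of the 2 values shown sits). Compound 3 `O=C(Nc1ccc(Nc2nccc(Nc3ccccc3Cl)n2)cc1)Nc1ccc(Cl)c(C(F)(F)F)c1` follows from compound 2 by one change, chloro in place of hydrogen on an aromatic carbon, ortho to a large group: chloro in place of hydrogen on an aromatic carbon. The same difference reads phenyl to 2-chlorophenyl.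

Among the compounds with values here, only one measured step bears on this group, an at least 1.3-fold higher number from compound 1 to compound 2 (0.11 log units; that floor lies within the scatter). That step replaces cyclopropyl with phenyl, so it does not measure the effect of chloro. With so little evidence, no step beyond the scatter is expected in this assay, and no direction can be favoured. Compound 3 is therefore expected to remain close to the limit of compound 2, and a second report as a limit would fit that expectation.

The estimated change is an at least 1.1-fold lower number from compound 2 to compound 3 (0.04 log units; that floor lies within the scatter). For compound 3 the estimated value is 45000 nM, with an expected range of 15000 nM to 90000 nM.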

Compound 3, half-maximal inhibitory concentration: 27900 nM
The estimate for compound 3 lay 1.6-fold (0.21 log units) above the measured number; low and high end bracket the measured number.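

In this assay compound 2 gives > 50000 nM, a limit of the assay and not a number. Chloro in place of hydrogen on an aromatic carbon, ortho to a large group, gives compound 3 a readable number where compound 2 has none, with an at least 1.7-fold lower number from compound 2 to compound 3 (0.25 log units; that floor lies within the scatter), and the true size of that step stays unknown because one end of it is: the limit of > 50000 nM in this assay, at which 1 of the 3 values shown sits.
Set against the cyclopropyl group on the same nitrogen, the step is a 1.4-fold lower number from compound 1 to compound 3 (0.14 log units; within the scatter), so 2-chlorophenyl and cyclopropyl are not separated on this read-out.

Open, from the compounds shown here alone, is whether the readable number belongs to chloro itself or would also come with fluoro, methyl or methoxy on the same aromatic carbon, and whether chloro on other carbons of that ring would behave alike. Also open, going by these compounds, is whether a different group on that nitrogen, such as morpholine, a longer alkyl chain or a pyridine, would give a step beyond the scatter in this assay.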